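This account rests on a few compounds, and the source may have more. Where it says the series, first, only, none or still open, it means among the compounds named here.

Measured compounds in an assay for inhibition of glucose-6-phosphatase catalytic subunit 1 (Rattus norvegicus), tested at 100 uM; on this read-out higher numbers stand for more inhibition at the one concentration tested (going by the name of the read-out) and lower numbers for less inhibition:
- compound 1 `CCOC(=O)C(C(=O)OCC)C(CC(=O)C[C@@H]1O[C@H](CO)[C@@H](O)[C@H](O)[C@H]1O)c1ccc2ccccc2c1`: 4.6%
- compound 2 `O=C(/C=C/c1ccccc1)C[C@@H]1O[C@H](CO)[C@@H](O)[C@H](O)[C@H]1O`: -49.7%
- compound 3 `O=C(/C=C/c1cccnc1)C[C@@H]1O[C@H](CO)[C@@H](O)[C@H](O)[C@H]1O`: -8.1%

Compound 1 stands highest of the three numbers in this assay; compound 3 is nearest, and compound 2 furthest below it. Among the measured compounds shown here, the only step measured within one place is a number 41.6 percentage points higher from compound 2 to compound 3 (beyond the scatter); it concerns the aryl group on the unsaturated chain of compound 2 and compound 3, not the saturated chain position that differs here.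

Compound 4 `CCOC(=O)C(C(=O)OCC)C(CC(=O)C[C@@H]1O[C@H](CO)[C@@H](O)[C@H](O)[C@H]1O)c1ccccc1` is not yet measured. It differs from compound 1 by phenyl in place of naphthalen-2-yl on a saturated chain carbon bound to two saturated chain carbons. For the measured compounds named here, no measured pair exchanges naphthalen-2-yl for phenyl, so the step from compound 2 to compound 3 bears on it only as a sign that changing the aryl group on a chain can move this assay by a large amount in either direction. The comparison of compound 1 with compound 2 is noted, but these two differ in more than one place, so only their values are read.

For compound 4 the expected step is a number 9.6 percentage points lower from compound 1 to compound 4 (within the scatter) in this assay, most likely not beyond the scatter, with a wide range. The estimate for compound 4 in this assay is -5%, expected between -35% and 20%.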

Compound 4, a percentage reported as inhibition, at one concentration (the size of the read-out at that concentration, not a potency): -3.3%
Beside the measured number, compound 4's estimate is 1.7 percentage points below it, and the stated range covers the measured number.
By their numbers in this assay, from the lowest: compound 2; then compounds 3, 4 and 1 (each within the scatter of the next, the first and the last beyond it).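

At the saturated chain carbon bound to two saturated chain carbons, the exchange of naphthalen-2-yl for phenyl gives a number 7.9 percentage points lower from compound 1 to compound 4 (within the scatter) in this assay, so this read-out does not separate the two aryl groups at this place. Among the compounds shown here, this is the first measured change at this position, and it contrasts with the aryl change on the unsaturated chain, a number 41.6 percentage points higher from compound 2 to compound 3 (beyond the scatter), so a large step at that place does not carry over to this exchange. No supporting measurement bears on why the two aryl groups read alike here.

As far as these compounds go, it remains open whether pyridin-3-yl, or a phenyl carrying an amine, would move the number beyond the scatter at this saturated position. Also open, from the compounds shown here alone, is how a carboxylic acid in place of the ethyl esters would read in this assay.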